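A few compounds are considered here, and "the series" means these few. Any claim that something is new, unique, unknown or untested is made for them only; others in the source may bear on it.

Three compounds of one series have numbers in a functional assay on HEp-2 cells (Homo sapiens) for cytotoxicity, read by sulforhodamine B assay, with a stated time of 48 h; a higher number here means a weaker inhibitor, a lower number a stronger inhibitor. Compound 1 `CC(=O)N1N=C(c2ccc(Br)cc2)CC1c1cccc(Cl)c1Cl` gives 50000 nM; compound 2 `CC(=O)N1N=C(c2ccco2)CC1c1cccc([N+](=O)[O-])c1` gives 30000 nM; compound 3 `CC(=O)N1N=C(c2ccco2)CC1c1ccc(Br)cc1` gives 51200 nM. All three numbers lie within the scatter of one another, so compound 3 stands level with compound 1 and with compound 2, and none of the three is set apart. Compound 4 `CC(=O)N1N=C(c2ccco2)CC1c1ccc(N(C)C)cc1` has not yet been measured. It differs from compound 3 by dimethylamino in place of bromo on an aromatic carbon. For the measured compounds named here, no measured pair shows the effect of this change, and the three numbers give no spread to build on. Compound 4 is expected to differ from its parent by a 1.1-fold lower number from compound 3 to compound 4 (0.06 log units; within the scatter), a step that stays within the scatter. In this assay compound 4 is estimated at 45000 nM, with a range from 20000 nM to 100000 nM.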

Compound 4, half-maximal inhibitory concentration: 16000 nM
Compound 4: middle estimate off by 2.8-fold (0.45 log units), on the high side; the measured number lies below the stated range.
By their numbers in this assay, from the lowest: compounds 4, 2, 1 and 3 (each within the scatter of the next, the first and the last beyond it).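

In this assay, for the compounds shown here, dimethylamino in place of bromo on an aromatic carbon, para to a large group, gives a 3.2-fold lower number from compound 3 to compound 4 (0.51 log units; beyond the scatter) and is the only single-place step so far. The earlier compounds shown here stood level and gave no reading of this position; it now proves able to move the number, though only modestly. No measurement on hand accounts for the step.

Going by these compounds, whether an unsubstituted amine, a methoxy group or a plain hydrogen at this position would give a similar number remains open. Also open, on these data alone, is whether dimethylamino would act alike on the core of compound 1.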